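Three Limits and One Shorter Nitrooxy Ester

The compounds below may be only part of what the source reports. "The series", "measured", "known", "first", "only" and "open" are said of these compounds alone.

Measured in a functional assay on M14 cells (Homo sapiens) for cytotoxicity, read by resazurin assay, with a stated time of 72 h (on this read-out higher numbers stand for weaker inhibition and lower numbers for stronger inhibition), each value being a limit of the assay and not a number:
Compound 1 `COc1cc(/C=C/C(=O)OCCCCCCO[N+](=O)[O-])ccc1O`: > 50000 nM
Compound 2 `O=C(/C=C/c1ccc(OCCCCCCO[N+](=O)[O-])c(O)c1)OCCCCCCO[N+](=O)[O-]`: > 50000 nM
Compound 3 `COc1cc(/C=C/C(=O)Oc2ccc(OCc3c(-c4ccccc4)no[n+]3[O-])cc2)ccc1O`: > 50000 nM

Compound 1 gives only a limit, > 50000 nM. It is not alone, as the series shows (the limit of > 50000 nM in this assay, at which 3 of the 3 values shown sit).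

Compound 4 `COc1cc(/C=C/C(=O)OCCCO[N+](=O)[O-])ccc1O` differs from compound 1 in one place: nitrooxy in place of 3-(nitrooxy)propyl on a saturated chain carbon, three bonds along the chain from an oxygen next to a carbonyl group. Nitrooxy stands in place of 3-(nitrooxy)propyl on a saturated chain carbon, three bonds along the chain from an oxygen next to a carbonyl group.

Among the compounds with values here, no measured pair shows what a single change does here. Within the data shown here, with the limit of compound 1 at > 50000 nM as the only guide, no step beyond the scatter is expected in this assay, in either direction.

The estimated value for compound 4 is 50000 nM, with an expected range from 25000 nM to 100000 nM.

This estimate means an expected a number no higher from compound 1 to compound 4 (the limit leaves the size open).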

Compound 4, half-maximal inhibitory concentration: 42600 nM
Compound 4: middle estimate off by 1.2-fold (0.07 log units), on the high side; the range from low to high includes it.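

Within the data shown here, compound 4 is the only compound here that gives a number and not a limit: the limit of > 50000 nM in this assay, at which 3 of the 4 values shown sit. Putting nitrooxy in place of 3-(nitrooxy)propyl at this saturated chain carbon gives an at least 1.1-fold lower number from compound 1 to compound 4 (0.06 log units; that floor lies within the scatter). Compound 1 has only a limit, so this step has a floor but no known size, and it does not establish that the shorter chain matters.

As far as these compounds go, it remains open how far the number would move with an amine or a carboxylic acid in place of the nitrooxy group. A chain longer than that of compound 1 is equally untested here.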